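This account rests on a few compounds, and the source may have more. Where it says the series, first, only, none or still open, it means among the compounds named here.

Compound 1 `Cc1nnc(CN(C)C)n1-c1ccc(Cl)cc1C(=O)c1ccccc1`: 2.2 mg/kg
Compound 2 `Cc1nnc(CN(C)C)n1-c1ccccc1C(=O)c1ccccc1Cl`: 22 mg/kg
Compound 3 `Cc1nnc(CN2CCCC2)n1-c1ccc(Cl)cc1C(=O)c1ccccc1Cl`: 1 mg/kg

These values come from a functional assay on the whole organism (strain CF-1) with Mus musculus as the target; on this read-out lower numbers stand for an effect already at smaller amounts and higher numbers for an effect only at larger amounts of compound. Compound 3 has the lowest number of the three; compound 1 gives a moderately higher value, beyond the usual scatter, and compound 2 a far higher one. Compound 4 `Cc1nnc(CN(C)C)n1-c1ccc(Cl)cc1C(=O)c1ccccc1Cl` differs from compound 3 by a single change: dimethylamino in place of pyrrolidin-1-yl on a saturated chain carbon bound to an aromatic carbon. Within the data shown here, no measured pair differs in only this place, so the size of this step has not been observed directly. Compound 1 also carries dimethylamino and, in this assay, gives a value only moderately above that of compound 3, so the step is expected to be small, if anything toward a slightly higher number. Compound 4 is therefore estimated at 1.8 mg/kg, within 0.7 mg/kg to 4.5 mg/kg. This estimate means an expected step of a 1.8-fold higher number from compound 3 to compound 4 (0.26 log units; within the scatter).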

Compound 4, dose for half-maximal effect: 0.25 mg/kg
Compound 4: the middle estimate sits 7.2-fold (0.86 log units) above what was measured; the measured number lies below the stated range.
By their numbers in this assay, from the lowest: compound 4; then compound 3; then compound 1; then compound 2.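

Dimethylamino in place of pyrrolidin-1-yl on a saturated chain carbon bound to an aromatic carbon gives a 4.0-fold lower number from compound 3 to compound 4 (0.60 log units; beyond the scatter), so the choice of amine at this position matters when both chloro groups are present. Chloro in place of hydrogen, on a different aromatic carbon in each case, gives an 8.8-fold lower number from compound 1 to compound 4 (0.94 log units; beyond the scatter) and an 88-fold lower number from compound 2 to compound 4 (1.94 log units; beyond the scatter), so each chloro group counts while the other is in place. As far as these compounds go, whether diethylamino or piperidin-1-yl at this position would give a still lower number stays open. Nothing given here explains these steps.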